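From cyclopropyl to isopropyl at a short half-life

The compounds below may be only part of what the source reports. "The series", "measured", "known", "first", "only" and "open" are said of these compounds alone.

Of the compounds shown here, two have so far been measured in an in vitro ADME assay on microsomes from liver (Rattus norvegicus) for metabolic stability, read by LC-MS, using NADPH, tested at 1 uM (a lower number here means that the compound disappears faster, a higher number that the compound lasts longer), and neither lasts long. Within the data shown here, compound 1 (`CC(C)CN1C(=O)CN(Cc2ccc(-c3ccc(F)c(CN4CCCC(C)C4)n3)cc2)C1=O`) shows 0.1 h as its half-life, and compound 2 (`O=C1CN(Cc2ccc(-c3ccc(F)c(CN4CCCCC4)n3)cc2)C(=O)N1CC1CC1`) shows 0.2 h as its half-life, so compound 2 stands within the scatter of compound 1, the only other number available.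

Compound 3 (`CC(C)CN1C(=O)CN(Cc2ccc(-c3ccc(F)c(CN4CCCCC4)n3)cc2)C1=O`) has not yet been measured. It departs from compound 2 by a single change (isopropyl in place of cyclopropyl on a saturated chain carbon bound to an amide-type nitrogen in a ring): isopropyl in place of cyclopropyl on a saturated chain carbon bound to an amide-type nitrogen in a ring. Cut one bond further out, the same difference reads cyclopropylmethyl to isobutyl.

Among the measured compounds shown here, no measured pair isolates this change, so the data give no direct size for it. The expectation in this assay is for no step beyond the scatter, in either direction. The estimated move a 1.3-fold lower number from compound 2 to compound 3 (0.12 log units; within the scatter) is expected to stay inside that scatter. For the measured compounds named here, this rests on compound 1 at 0.1 h and compound 2 at 0.2 h as the only numbers at hand. For compound 3 the estimated half-life is 0.15 h with an expected range from 0.08 h to 0.3 h on repeated measurement.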

Compound 3, half-life: 0.15 h
Compound 3: middle estimate and measured number agree at the digits printed, and the stated range covers the measured number.
By their numbers in this assay, from the lowest: compounds 1, 3 and 2 (each within the scatter of the next).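

In this assay, the exchange of cyclopropyl for isopropyl on a saturated chain carbon bound to an amide-type nitrogen in a ring now has a size of its own: a 1.3-fold lower number from compound 2 to compound 3 (0.12 log units; within the scatter) and so stays within the scatter, with the ring-free group and the three-membered ring reading alike at this place. Compound 3 also isolates the other difference between the first two compounds, since hydrogen in place of methyl on a saturated ring carbon gives a 1.5-fold higher number from compound 1 to compound 3 (0.18 log units; within the scatter) and likewise stays within the scatter. No measurement is at hand that bears on why these half-lives take the values they do.

As far as these compounds go, both steps were read among short half-lives, with compound 3 at 0.15 h in this assay, so it remains open whether either exchange would look the same on a compound that lasts longer. Also open, from the compounds shown here alone, is whether a different kind of group at the same place, such as a carboxylic acid, an amine or a longer chain, would produce a step beyond the scatter.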